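A few compounds are considered here, and "the series" means these few. Any claim that something is new, unique, unknown or untested is made for them only; others in the source may bear on it.

Measured so far in an assay on cell membranes for inhibition of P2Y purinoceptor 1 (Meleagris gallopavo); a higher number here means a weaker inhibitor, a lower number a stronger inhibitor:
- compound 1, `CNc1nc(Cl)nc2c1ncn2C[C@H]1[C@H](COP(=O)(O)O)[C@@H]1COP(=O)(O)O`: 1740 nM
- compound 2, `CNc1nc(Cl)nc2c1ncn2C[C@@H]1[C@H](COP(=O)(O)O)[C@@H]1COP(=O)(O)O`: 2170 nM

Within the data shown here, compound 2 stands at the higher of the two numbers in this assay, with compound 1 as its only neighbour; the gap between them is a 1.2-fold higher number from compound 1 to compound 2 (0.10 log units; within the scatter), so the two values cannot be told apart. That step rests on (the fact that compounds 1 and 2 differ only in the configuration as drawn).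

Compound 3, `CNc1nc(Cl)nc2c1ncn2CC1[C@H](COP(=O)(O)O)[C@H]1COP(=O)(O)O`, is not yet measured. It differs from compound 2 by the two compounds have the same atoms and bonds; at least one stereo element is drawn with a configuration in one of them and without one in the other: 2 of 3 stereo elements differ; a stereocentre at a saturated ring carbon is drawn r in compound 2 and without a configuration in compound 3; a stereocentre at a saturated ring carbon is drawn R in compound 2 and S in compound 3. Among the measured compounds shown here, the only measured step that bears on a change of this kind is a 1.2-fold higher number from compound 1 to compound 2 (0.10 log units; within the scatter), where a single ring stereocentre was inverted and the number did not move beyond the scatter. Compound 3 again keeps all atoms and bonds of the shared core and the two phosphate-bearing arms, changing only configuration at ring carbons, one of them now left undefined. On that single precedent no step beyond the scatter is expected in this assay, in either direction.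

For compound 3 the estimate is therefore 2100 nM in this assay, with a range of 700 nM to 6500 nM. The expected step from compound 2 to compound 3 is accordingly a 1.0-fold lower number from compound 2 to compound 3 (0.01 log units; within the scatter).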

Compound 3, half-maximal inhibitory concentration: 2700 nM
The estimate for compound 3 lay 1.3-fold (0.11 log units) below the measured number, within the range that was stated.
By their numbers in this assay, from the lowest: compounds 1, 2 and 3 (each within the scatter of the next).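

Two of the three stereo elements differing at once, with a saturated ring carbon left without a configuration, still gives no step beyond the scatter in this assay: there is a 1.2-fold higher number from compound 2 to compound 3 (0.09 log units; within the scatter) and a 1.6-fold higher number from compound 1 to compound 3 (0.19 log units; within the scatter). Among these compounds, the earlier pair covered only a single inverted ring stereocentre, whereas the three compounds now cover a wider set of configurations at the ring carbons and still cannot be told apart in this assay. The number for compound 3 cannot be tied to one full configuration, and this limits the comparison with both defined compounds: the fact that one of compounds 1 and 3 is drawn with a defined configuration and the other without, at the place where they differ The same limit applies to the step from the other defined compound: the fact that one of compounds 2 and 3 is drawn with a defined configuration and the other without, at the place where they differ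

The compounds shown do not separate what the undefined ring carbon and the inverted ring carbon each contribute in compound 3. They also keep the shared core and both phosphate-bearing arms unchanged, leaving open whether configuration matters as little in this assay with a carboxylic acid in place of a phosphate or with a longer chain carrying it.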